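This account rests on a few compounds, and the source may have more. Where it says the series, first, only, none or still open, it means among the compounds named here.

Compound 2 `CCN1CCN(c2cc(C)c3cc(NC(=O)c4cc(Cl)cc(Cl)c4)ccc3n2)CC1` is the strongest of the three measured compounds in a functional assay on SK-BR-3 cells (Homo sapiens) for antiproliferative activity, read by MTT assay, with a stated time of 72 h (a higher number here means a weaker inhibitor, a lower number a stronger inhibitor), where compound 2 gives 2660 nM. Compound 1 `CCN1CCN(c2cc(C)c3cc(NC(=O)c4ccccc4F)ccc3n2)CC1` gives 38100 nM in this assay, and compound 3 `Cc1cc(N2CCCCC2)nc2ccc(NC(=O)c3ccc(Cl)c(Cl)c3)cc12` gives 42500 nM. The new compound 4 `CCN1CCN(c2cc(C)c3cc(NC(=O)c4ccccc4Br)ccc3n2)CC1` differs from compound 2 in one place: 2-bromophenyl in place of 3,5-dichlorophenyl on a carbonyl carbon. For the measured compounds named here, the one measured step that bears on this change is a 14-fold lower number from compound 1 to compound 2 (1.16 log units; beyond the scatter), which runs in the opposite direction, from a singly substituted ring to the 3,5-dichlorophenyl group. Reversing that change, from 3,5-dichlorophenyl back to a single halogen on the phenyl ring, leads one to expect a markedly weaker inhibitor, so compound 4 is estimated at 20000 nM, within 6000 nM to 60000 nM, an expected step of a 7.5-fold higher number from compound 2 to compound 4 (0.88 log units; beyond the scatter).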

Compound 4, half-maximal inhibitory concentration: 39200 nM
Beside the measured number, compound 4's estimate is 2.0-fold (0.29 log units) below it; low and high end bracket the measured number.
By their numbers in this assay, from the lowest: compound 2; then compounds 1, 4 and 3 (each within the scatter of the next).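

In this assay the change to 2-bromophenyl gives a 15-fold higher number from compound 2 to compound 4 (1.17 log units; beyond the scatter), so the low number of compound 2 is not kept with this single halogen. Bromo in place of fluoro on an aromatic carbon gives a 1.0-fold higher number from compound 1 to compound 4 (0.01 log units; within the scatter), so the two singly substituted groups cannot be told apart here, and among these compounds only the 3,5-dichlorophenyl group stands out. Nothing given here accounts for this difference. From the compounds shown here alone, it remains open whether an amine, a methoxy group or a carboxylic acid on this phenyl ring would give a number nearer that of compound 2 or compound 4.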